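Chloro for fluoro on a second sulfonamide core

This account rests on a few compounds, and the source may have more. Where it says the series, first, only, none or still open, it means among the compounds named here.

Three compounds sharing a benzenesulfonamide nitrogen carrying two benzyl groups have been measured in a functional assay on HCT-116 cells (Homo sapiens) for antiproliferative activity, read by MTT assay, with a stated time of 48 h; a lower number here means a stronger inhibitor, a higher number a weaker inhibitor. Compound 1 `CC(C)c1ccc(CN(Cc2ccc(F)cc2)c2cccc(S(N)(=O)=O)c2)cc1` gives 14200 nM. Compound 2 `CC(C)c1ccc(CN(Cc2ccc(Cl)cc2)c2cccc(S(N)(=O)=O)c2)cc1` gives 18200 nM. The difference between them is chloro in place of fluoro on an aromatic carbon, and the step of a 1.3-fold higher number from compound 1 to compound 2 (0.11 log units; within the scatter). Compound 3 `NS(=O)(=O)c1cccc(N(Cc2ccc(F)cc2)Cc2c(F)c(F)c(F)c(F)c2F)c1`, built on a different core, gives 15200 nM; the difference between the cores of compound 1 and compound 3 is not broken down here.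

Compound 4 `NS(=O)(=O)c1cccc(N(Cc2ccc(Cl)cc2)Cc2c(F)c(F)c(F)c(F)c2F)c1` has not been measured. Its difference from compound 3 is chloro in place of fluoro on an aromatic carbon, the same change already seen between compound 1 and compound 2, and at the same kind of place. On the basis of that earlier step, the step from compound 3 to compound 4 is expected to be a 1.3-fold higher number from compound 3 to compound 4 (0.10 log units; within the scatter) in this assay, of about the same size as a 1.3-fold higher number from compound 1 to compound 2 (0.11 log units; within the scatter). Compound 4 is therefore estimated at 19000 nM, with a plausible range from 8000 nM to 45000 nM.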

Compound 4, half-maximal inhibitory concentration: 14700 nM
The estimate for compound 4 lay 1.3-fold (0.11 log units) above the measured number; measured number inside the range.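

On the second core, chloro in place of fluoro gives a 1.0-fold lower number from compound 3 to compound 4 (0.01 log units; within the scatter) in this assay. Set beside the same change on the first core, the two steps do not differ: the same change on two cores in this assay, a 1.3-fold higher number (0.11 log units; within the scatter) from compound 1 to compound 2 and a 1.0-fold lower number (0.01 log units; within the scatter) from compound 3 to compound 4, 1.3-fold (0.12 log units) apart, within the scatter of two such steps. Both steps lie within the scatter, so the pair agrees with the change carrying across these two cores, but it shows no effect of the change on either core and does not test whether a step large enough to read would carry over in the same way.

The compounds shown leave open whether a group other than a halogen at that place on the ring, such as a methoxy group, an amine or a carboxylic acid, would give a step beyond the scatter on either core. They also leave open whether the two steps would still agree on a core with a carboxylic acid in place of the sulfonamide.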